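Ring swap from compound 3 to compound 4

The source may report more compounds than this note shows. Statements on the series, on what has been measured and on what is new or still open speak of the compounds shown alone.

Going by the values given here, in an ADME assay on Caco-2 cells (Homo sapiens) for permeability, read by LC-MS, in the apical to basolateral direction, with a stated time of 90 min (on this read-out higher numbers stand for higher permeability and lower numbers for lower permeability), three members have numbers so far. Compound 1 `Cc1cc(-c2ncccn2)cc(C(=O)NNS(=O)(=O)c2ccccc2)c1F` gives 77 10^-6 cm/s, compound 2 `Cc1cc(-n2cccn2)cc(C(=O)NNS(=O)(=O)c2ccccc2)c1F` gives 48 10^-6 cm/s, and compound 3 `Cc1cc(-c2ccccn2)cc(C(=O)NNS(=O)(=O)c2ccccc2)c1F` gives 63 10^-6 cm/s. On these numbers compound 3 cannot be told apart from the other two. The data show a 1.2-fold lower number from compound 1 to compound 3 (0.09 log units; within the scatter) and a 1.3-fold higher number from compound 2 to compound 3 (0.12 log units; within the scatter).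

The next member, compound 4 `Cc1cc(-n2nccn2)cc(C(=O)NNS(=O)(=O)c2ccccc2)c1F`, has no number yet in this assay. The change is 2H-1,2,3-triazol-2-yl in place of pyridin-2-yl on an aromatic carbon, para to a fluoro group and meta to a methyl group.

Among the compounds with values here, no measured step contains the entering group, so the guidance is indirect. The nearest counterpart is the 1H-pyrazol-1-yl of compound 2, and swapping that group for pyridin-2-yl gave only a 1.3-fold higher number from compound 2 to compound 3 (0.12 log units; within the scatter). The remaining swap at this carbon, a 1.6-fold lower number from compound 1 to compound 2 (0.21 log units; within the scatter), also stays small. On these data alone, all three measured swaps at this position lie within the scatter, although three compounds are a thin basis and the new group is untested.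

No change beyond the scatter is expected, and the estimated step is a 1.1-fold lower number from compound 3 to compound 4 (0.06 log units; within the scatter). The estimate for compound 4 is 55 10^-6 cm/s, with an expected range of 30 10^-6 cm/s to 95 10^-6 cm/s.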

Compound 4, apparent permeability: 53 10^-6 cm/s
Beside the measured number, compound 4's estimate is 1.0-fold (0.02 log units) above it; measured number inside the range.
By their numbers in this assay, from the lowest: compounds 2, 4, 3 and 1 (each within the scatter of the next).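

Compound 4 places a five-membered aromatic ring with 3 hetero atoms on the aromatic carbon para to a fluoro group and meta to a methyl group, and in this assay the swap for pyridin-2-yl gives a 1.2-fold lower number from compound 3 to compound 4 (0.08 log units; within the scatter) as its step. The other two comparisons for the same group, a 1.1-fold higher number from compound 2 to compound 4 (0.04 log units; within the scatter) and a 1.5-fold lower number from compound 1 to compound 4 (0.16 log units; within the scatter), are also printed as within the scatter, so all four groups at this carbon, five-membered and six-membered aromatic rings alike, now stand within the scatter of one another in this assay, and none of the four compounds goes against this. Nothing at hand gives a reason for this flat picture, and the series offers no supporting data that would explain these steps.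

Every group shown at this carbon is an aromatic ring joined directly to the core, so the effect of an amine, a carboxylic acid, a morpholine ring or a longer chain at the same place remains open. Also open, on these data alone, is whether the same flat picture would hold with the methyl or fluoro group replaced, for instance by a chloro group or a methoxy group, elsewhere on the shared core.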